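Benzylamide in place of a carboxy group: cytotoxicity notes

The source may hold more compounds than are shown below. What is called first, only, known or untested is meant among the compounds shown, and "the series" means these compounds.

Measured in a functional assay on Huh-5-2 cells (Homo sapiens), read by MTT assay; a higher number here means that more compound is tolerated, a lower number that less compound is tolerated:
- Compound 1 `O=C(O)c1ccc2c(c1)nc(-c1ccc(OCc3cc(Cl)ccc3-c3cccc(Cl)c3)cc1)n2C1CCCCC1`: 32000 nM
- Compound 2 `O=C(O)c1ccc(-c2ccc(Cl)cc2)c(COc2ccc(-c3nc4cc(C(=O)O)ccc4n3C3CCCCC3)cc2)c1`: > 50000 nM, a limit of the assay

Compound 2 has no exact number in this assay. Its > 50000 nM is a limit and not a number. Going by the values given here, the series so far shows (the limit of > 50000 nM in this assay, at which 1 of the 2 values shown sits).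

Compound 3 `O=C(O)c1ccc2c(c1)nc(-c1ccc(OCc3cc(C(=O)NCc4ccccc4)ccc3-c3ccc(Cl)cc3)cc1)n2C1CCCCC1` keeps the rest of compound 2 and carries benzylamino in place of hydroxy on a carbonyl carbon whose other neighbours are: aromatic carbon (benzylamino in place of hydroxy on a carbonyl carbon). The same difference reads as carboxy to benzylcarbamoyl.

Among the compounds with values here, no measured step covers this change, so the expectation is loose. Within the data shown here, the only exact number available is that of compound 1 at 32000 nM, and it anchors the guess. A modest move towards less compound tolerated is expected, and it may not clear the usual scatter. The estimated change is an at least 1.6-fold lower number from compound 2 to compound 3 (0.22 log units; that floor lies within the scatter). A reading that again returns only a limit would not be surprising.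

For compound 3 the expected value is 30000 nM, with an estimated range of 12000 nM to 50000 nM.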

Compound 3, half-maximal cytotoxic concentration: 22000 nM
Compound 3: middle estimate off by 1.4-fold (0.13 log units), on the high side, within the range that was stated.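

In this assay, going by these compounds alone, benzylamino in place of hydroxy on a carbonyl carbon whose other neighbours are: aromatic carbon, gives an at least 2.2-fold lower number from compound 2 to compound 3 (0.35 log units; beyond the scatter), so this position is not indifferent to the change from carboxy to benzylcarbamoyl, something the earlier compounds alone offered no step to show. Compound 2 stands at > 50000 nM, which is a limit of the assay and not a number. The step is therefore only a floor and its true size stays unknown, because one of its two ends rests on a limit: the limit of > 50000 nM in this assay, at which 1 of the 3 values shown sits.

On these data alone, whether the lower number in this assay goes with the amide link or with the added aromatic ring remains open, and a plain primary carboxamide or an N-methyl amide on the same carbonyl carbon would separate the two. Also open, as far as these compounds go, is whether a longer chain such as phenethylamino, or a cyclohexylmethylamino group with no aromatic ring, would shift the number further or leave it where compound 3 stands at 22000 nM.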